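Branching the sulfonamide chain in a kinase inhibitor series

The source may hold more compounds than are shown below. What is called first, only, known or untested is meant among the compounds shown, and "the series" means these compounds.

Measured compounds:
- compound 1, `CCCCNS(=O)(=O)c1ccc(Nc2ncc3c(n2)N(C2CCCC2)[C@H](CC)C(=O)N3C)cc1`: 19.9 nM
- compound 2, `CC[C@@H]1C(=O)N(C)c2cnc(-n3ccc4cc(C(=O)NC(C)C)ccc43)nc2N1C1CCCC1`: 17.4 nM

Of the compounds shown here, two have been measured in an assay for inhibition of serine/threonine-protein kinase PLK2 (Homo sapiens), read by FRET and Z'-LYTE, with a stated time of 1 h; on this read-out lower numbers stand for stronger inhibition and higher numbers for weaker inhibition. Compound 1 gives 19.9 nM, the higher of the two numbers, and compound 2 gives 17.4 nM. The gap between them lies within the scatter of repeated measurements, so the two cannot be told apart on these data, and compound 2 differs from compound 1 in more than one place.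

Compound 3, `CC[C@@H]1C(=O)N(C)c2cnc(Nc3ccc(S(=O)(=O)NCC(C)C)cc3)nc2N1C1CCCC1`, has not yet been measured. It differs from compound 1 in one place: isopropyl in place of propyl on a saturated chain carbon bound to a sulfonamide nitrogen. The two compounds hold the same atoms, joined differently, and the change sits far from the shared core, at the end of the chain on the sulfonamide nitrogen. For the measured compounds named here, no measured pair in this set shows what such a change does.

On that basis the step from compound 1 to compound 3 is expected to be small, with no direction that stands out beyond the scatter, namely a 1.0-fold higher number from compound 1 to compound 3 (0.00 log units; within the scatter). Compound 3 is therefore estimated at 20 nM, in a range from 8 nM to 50 nM.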

Compound 3, half-maximal inhibitory concentration: 21.8 nM
Estimate against measurement, compound 3: 1.1-fold (0.04 log units) below, within the range that was stated.
By their numbers in this assay, from the lowest: compounds 2, 1 and 3 (each within the scatter of the next).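

In this assay, isopropyl in place of propyl on a saturated chain carbon bound to a sulfonamide nitrogen gives a 1.1-fold higher number from compound 1 to compound 3 (0.04 log units; within the scatter), so the two compounds cannot be told apart. For the compounds shown here, this is the first pair in the set that differs in one place, and it gives the first direct reading at this position: butyl and isobutyl on the sulfonamide nitrogen, chains with the same atoms joined differently, give numbers that lie within the scatter of each other. Nothing measured here accounts for how close the two numbers lie.

The compounds shown cover only these two chains on the sulfonamide nitrogen, so it remains open whether a longer chain such as hexyl, a ring-bearing group such as cyclopropylmethyl, or a chain ending in an amine or a carboxylic acid would give a number beyond the scatter. Going by these compounds alone, it also remains open whether the same change would read alike on a compound with a different core or a different group at the far end, since compound 2 carries no sulfonamide and offers no such pair.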